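The compounds below may be only part of what the source reports. "The series", "measured", "known", "first", "only" and "open" are said of these compounds alone.

Series notes. For the measured compounds named here, compound 1 `O=C(/C=C\Nc1ccc(F)cc1)c1nc(-c2ccc(F)cc2)n2ccccc12` is the only member with a number in a functional assay on A549 cells (Homo sapiens) for cytotoxicity, read by MTT assay, with a stated time of 48 h; a higher number here means a weaker inhibitor, a lower number a stronger inhibitor: compound 1 gives 13200 nM. Compound 3 `O=C(/C=C\Nc1ccc(F)cc1)c1nc(-c2ccc(C(F)(F)F)cc2)n2ccccc12` carries trifluoromethyl in place of fluoro on an aromatic carbon; in this assay compound 3 returns a limit, > 30000 nM. That gives an at least 2.2-fold higher number from compound 1 to compound 3 (0.35 log units; beyond the scatter). Compound 2 `O=C(/C=C\Nc1ccc2cc[nH]c2c1)c1nc(-c2ccc(C(F)(F)F)cc2)n2ccccc12` also returns a limit in this assay, > 30000 nM. Both sit at the limit of > 30000 nM in this assay, at which 2 of the 3 values shown sit, so the step that the two limits leave unreadable from compound 2 to compound 3, the one closest to the present question, cannot be read.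

Compound 4 `Cc1cc2cc(N/C=C\C(=O)c3nc(-c4ccc(F)cc4)n4ccccc34)ccc2[nH]1` differs from compound 1 by 2-methyl-1H-indol-5-yl in place of 4-fluorophenyl on an amine nitrogen. Going by the values given here, no measured step bears on this change with a readable size: the change on the amine nitrogen from compound 2 to compound 3 leaves nothing to carry over, and the trifluoromethyl step concerns the aromatic carbon, not the amine nitrogen. The expected step is a 1.0-fold lower number from compound 1 to compound 4 (0.01 log units; within the scatter), not beyond the scatter. The estimate for compound 4 in this assay is 13000 nM, within 5000 nM to 30000 nM.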

Compound 4, half-maximal inhibitory concentration: > 30000 nM
Compound 4 ended at the assay's limit; the forecaster's own chance of this, stated with the estimate: 35%; middle value at least 2.3-fold (0.36 log units) away from the limit.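

On the amine nitrogen, the change now has a readable direction in this assay: 2-methyl-1H-indol-5-yl in place of 4-fluorophenyl gives an at least 2.2-fold higher number from compound 1 to compound 4 (0.35 log units; beyond the scatter). For the compounds shown here, the earlier step on this nitrogen could not be read, so this is the first sign that the group held there matters, here with fluoro kept on the aromatic carbon, and that an indole-bearing group does not preserve the measured activity of compound 1. The step gives only a minimum size, and a single number remains in the series: the limit of > 30000 nM in this assay, at which 3 of the 4 values shown sit.

Going by these compounds, whether any group on the amine nitrogen can give a lower number than compound 1 stays open, for example a piperidine or a short chain ending in a carboxylic acid. Also open, on these data alone, is how far the number rises on leaving 4-fluorophenyl, since compound 4 gives no number beyond its limit.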